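The source may hold more compounds than are shown below. What is called first, only, known or untested is meant among the compounds shown, and "the series" means these compounds.

In a functional assay on CHO cells for agonist activity at Alpha-1A adrenergic receptor (Homo sapiens), read by FLIPR and calcium flux (a lower number here means a smaller maximal response, a higher number a larger maximal response), compound 3 `Cc1oncc1-c1cccc2c1CCC2c1ncc[nH]1` gives 63%, the largest of the three numbers available. Compound 2 `Cc1c(OCC2=NCCN2)ccc(Cl)c1NS(C)(=O)=O` gives 60%, which falls within the usual scatter of the result for compound 3, while compound 1 `COc1c(Cl)ccc2c1CCC2c1ncc[nH]1` gives 24%, a number well beyond the scatter below it. Compound 4 `c1cncc(-c2cccc3c2CCC3c2ncc[nH]2)c1` has not yet been measured; it differs from compound 3 by pyridin-3-yl in place of 5-methyl-1,2-oxazol-4-yl on an aromatic carbon. Within the data shown here, no pair of measured compounds shows what such an exchange does to the maximal response, so the direction cannot be read from the data. A moderate step is expected, most likely downward and near the edge of the scatter, giving the expected step of a number 8 percentage points lower from compound 3 to compound 4 (within the scatter). For compound 4 the estimate is 55%, expected to fall between 35% and 75%.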

Compound 4, largest response reached (Emax), in percent of the reference or control that the assay uses: 36%
The estimate for compound 4 lay 19 percentage points above the measured number, and the stated range covers the measured number.
By their numbers in this assay, from the lowest: compound 1; then compound 4; then compounds 2 and 3 (each within the scatter of the next).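

In this assay, among these compounds, placing pyridin-3-yl in place of 5-methyl-1,2-oxazol-4-yl on this aromatic carbon gives a number 27 percentage points lower from compound 3 to compound 4 (beyond the scatter) and provides the first direct reading of a change at this position. The two groups have the same heavy-atom count but differ in ring size and hetero atoms, so the maximal response here depends on more than the number of heavy atoms in the group. No measurement available here explains the drop. Still open, on these data alone, is how a plain phenyl ring or a morpholine would compare on this aromatic carbon. Also open, as far as these compounds go, is whether the methyl of 5-methyl-1,2-oxazol-4-yl matters on its own.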